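This account rests on a few compounds, and the source may have more. Where it says the series, first, only, none or still open, it means among the compounds named here.

Compound 3 `Cc1cn[nH]c1C(=O)Nc1sc2c(c1C(N)=O)CC(C)(C)OC2(C)C` sits second highest of the three numbers measured in an assay on cells for positive allosteric modulation of Cystic fibrosis transmembrane conductance regulator variant G551D (Homo sapiens), with stated times of 10 min and 2 min, in the presence of a further agent that is not named here (a lower number here means that less compound is needed, a higher number that more compound is needed for the effect), where compound 3 gives 123 nM. Its nearest neighbour is compound 1 `CC1(C)Cc2c(sc(NC(=O)c3ccccc3O)c2C(N)=O)C(C)(C)O1`, which gives 162 nM; the furthest is compound 2 `CC1(C)Cc2c(sc(NC(=O)c3[nH]ncc3Cl)c2C(N)=O)C(C)(C)O1`, which gives 81 nM. The step of a 1.3-fold lower number from compound 1 to compound 3 (0.12 log units; within the scatter) and the step of a 1.5-fold higher number from compound 2 to compound 3 (0.18 log units; within the scatter) both lie within the scatter, as does the step of a 2.0-fold lower number from compound 1 to compound 2 (0.30 log units; within the scatter).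

Compound 4 `CC1(C)Cc2c(sc(NC(=O)c3cc(C(F)(F)F)n[nH]3)c2C(N)=O)C(C)(C)O1` differs from compound 3 in one place: 3-(trifluoromethyl)-1H-pyrazol-5-yl in place of 4-methyl-1H-pyrazol-5-yl on a carbonyl carbon. The measured step that bears most directly on this change is a 1.5-fold higher number from compound 2 to compound 3 (0.18 log units; within the scatter), a swap of one small substituent on the same five-membered ring, which did not move the number beyond the scatter. The exchanges of the whole acyl group, a 2.0-fold lower number from compound 1 to compound 2 (0.30 log units; within the scatter) and a 1.3-fold lower number from compound 1 to compound 3 (0.12 log units; within the scatter), were likewise small. On that basis no step beyond the scatter is expected in this assay, so for compound 4 the estimate is a 1.1-fold lower number from compound 3 to compound 4 (0.05 log units; within the scatter). Compound 4 is therefore expected to give about 110 nM, with a range from 45 nM to 270 nM.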

Compound 4, half-maximal effective concentration: 130 nM
Compound 4: the middle estimate sits 1.2-fold (0.07 log units) below what was measured; the range from low to high includes it.
By their numbers in this assay, from the lowest: compounds 2, 3, 4 and 1 (each within the scatter of the next).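

On the carbonyl carbon, 3-(trifluoromethyl)-1H-pyrazol-5-yl replaces 4-methyl-1H-pyrazol-5-yl in this assay with a 1.1-fold higher number from compound 3 to compound 4 (0.02 log units; within the scatter) and no change beyond the scatter, so the larger group on the pyrazole leaves the number where it was. The further steps, a 1.6-fold higher number from compound 2 to compound 4 (0.21 log units; within the scatter) and a 1.2-fold lower number from compound 1 to compound 4 (0.10 log units; within the scatter) as well, also stay within the scatter, and the four acyl groups shown are not told apart by this assay. No measurement is at hand that would account for this flat result.

Going by these compounds, whether an amine, a carboxylic acid or a longer chain on the pyrazole would also leave the number unmoved remains open. On these data alone, all four compounds share one core, so how the number responds to changes outside the acyl group also remains open.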